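The source may report more compounds than this note shows. Statements on the series, on what has been measured and on what is new or still open speak of the compounds shown alone.

Compound 1 `COc1ccc(Cl)cc1NS(=O)(=O)c1ccc(OC)c(N2CCNCC2)c1` stands lowest of the two numbers measured in an assay on isolated protein for binding affinity to 5-hydroxytryptamine receptor 6 (Homo sapiens) (on this read-out higher numbers stand for weaker inhibition and lower numbers for stronger inhibition), where compound 1 gives 1.26 nM. Compound 2 `COc1ccc(S(=O)(=O)Nc2cc(Cl)c(Cl)cc2Cl)cc1N1CCNCC1` carries a 2,4,5-trichlorophenyl on the sulfonamide nitrogen in place of the 5-chloro-2-methoxyphenyl of compound 1, and in this assay compound 2 gives 5.01 nM; the measured step is a 4.0-fold higher number from compound 1 to compound 2 (0.60 log units; beyond the scatter), a modest move toward a weaker number. Compound 3 `COc1ccc(S(=O)(=O)Nc2cc(Br)cc(Br)c2F)cc1N1CCNCC1` is the next member of the set, and it differs from compound 1 by 3,5-dibromo-2-fluorophenyl in place of 5-chloro-2-methoxyphenyl on a sulfonamide nitrogen. As in the earlier step, the 5-chloro-2-methoxyphenyl gives way on the sulfonamide nitrogen to a ring that carries no hydrogen-bond acceptor and several halogens, so the step from compound 1 to compound 2 is the one that bears on this change. Compound 3 is therefore expected to show a modest rise rather than a drop, estimated as a 3.2-fold higher number from compound 1 to compound 3 (0.50 log units; beyond the scatter). Going by the values given here, the estimate for compound 3 is 4 nM, within a range from 1.3 nM to 13 nM, wide because a single comparable step a 4.0-fold higher number from compound 1 to compound 2 (0.60 log units; beyond the scatter) is the only guide.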

Compound 3, inhibition constant: 2.51 nM
For compound 3 the middle estimate is 1.6-fold (0.20 log units) above the measured one; the measured number falls inside the stated range.
By their numbers in this assay, from the lowest: compounds 1, 3 and 2 (each within the scatter of the next, the first and the last beyond it).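

In this assay, the exchange on the sulfonamide nitrogen gives a 2.0-fold higher number from compound 1 to compound 3 (0.30 log units; within the scatter), so a second ring without a hydrogen-bond acceptor, this one a 3,5-dibromo-2-fluorophenyl, stays within the scatter of the 5-chloro-2-methoxyphenyl, whereas the 2,4,5-trichlorophenyl of compound 2 alone had given a step beyond it. Losing that group at this position therefore does not always carry a measurable cost, and compound 2 is the one that goes against such a reading; the two halogenated rings themselves cannot be told apart, with a 2.0-fold lower number from compound 2 to compound 3 (0.30 log units; within the scatter). No measurement at hand accounts for why the two halogenated rings sit where they do relative to compound 1.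

Going by these compounds alone, with only three groups at this position, all of them substituted phenyl rings, it remains open how an unsubstituted phenyl or a ring with a single bromine or fluorine would compare. On these data alone, it is equally open whether a ring carrying a carboxylic acid or an amine on the sulfonamide nitrogen would keep the number in this range.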